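Methyl in place of hydrogen on a methoxy chain

A few compounds are considered here, and "the series" means these few. Any claim that something is new, unique, unknown or untested is made for them only; others in the source may bear on it.

Two compounds share a core and differ in two places. Compound 1 `CCOc1nc(-c2cc3ccccc3o2)cc(-c2ccc(Cl)cc2Cl)c1C#N` carries an ethoxy group and a dichlorinated aryl group; compound 2 `COc1nc(-c2cc3ccccc3o2)cc(-c2ccc(F)cc2)c1C#N` carries a methoxy group and a fluorinated aryl group. In a functional assay on aorta (strain Wistar) for inhibition, with Thoracic aorta (Rattus norvegicus) as the target (a higher number here means a weaker inhibitor, a lower number a stronger inhibitor), compound 2 gives 321000 nM. In this assay compound 1 gives 442000 nM, and the two numbers lie within the usual scatter of each other, so nothing separates them. Compound 3 `CCOc1nc(-c2cc3ccccc3o2)cc(-c2ccc(F)cc2)c1C#N` is compound 2 with one alteration: methyl in place of hydrogen on a saturated chain carbon bound to an oxygen on an aromatic ring. Within the data shown here, no measured pair differs in this place alone, so no step for it is known. Compound 3 is expected to give a number close to that of compound 2, with a step of a 1.0-fold higher number from compound 2 to compound 3 (0.01 log units; within the scatter) that stays within the scatter in either direction. For compound 3 the estimate in this assay is 330000 nM, with a range from 150000 nM to 700000 nM.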

Compound 3, half-maximal inhibitory concentration: 396000 nM
For compound 3 the middle estimate is 1.2-fold (0.08 log units) below the measured one; low and high end bracket the measured number.
By their numbers in this assay, from the lowest: compounds 2, 3 and 1 (each within the scatter of the next).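

In this assay, methyl in place of hydrogen on a saturated chain carbon bound to an oxygen on an aromatic ring, which turns methoxy into ethoxy, now has a measured step of its own: a 1.2-fold higher number from compound 2 to compound 3 (0.09 log units; within the scatter). This place therefore tolerates the change without any reading beyond the scatter, and the same holds on the aryl side, where 4-fluorophenyl in place of 2,4-dichlorophenyl on an aromatic carbon gives a 1.1-fold lower number from compound 1 to compound 3 (0.05 log units; within the scatter). No measurement is at hand that would explain either step.

With only methoxy and ethoxy at this place, the compounds shown leave open whether a longer chain, such as butoxy, would move the number beyond the scatter. They also leave open what an amine or a carboxylic acid at the end of that chain would do.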